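Swapping the sulfur-linked group: compound 3 to compound 4

A few compounds are considered here, and "the series" means these few. Any claim that something is new, unique, unknown or untested is made for them only; others in the source may bear on it.

- Compound 1 (`C#CCSc1nc(Sc2nc(C)c(C)s2)c(C#N)c(-c2cc(OC)c(OC)c(OC)c2)n1`): > 20000 nM (a limit)
- Compound 2 (`C#CCSc1nc(Sc2nncs2)c(C#N)c(-c2cc(OC)c(OC)c(OC)c2)n1`): 9820 nM
- Compound 3 (`C#CCSc1nc(Sc2nc3ccccc3s2)c(C#N)c(-c2cc(OC)c(OC)c(OC)c2)n1`): > 20000 nM (a limit)

In a functional assay on MCF7 cells (Homo sapiens) for antiproliferative activity, read by MTT assay, with a stated time of 72 h (on this read-out lower numbers stand for stronger inhibition and higher numbers for weaker inhibition), compound 3 gives only a limit (> 20000 nM) and no number. This is the limit of > 20000 nM in this assay, at which 2 of the 3 values shown sit, and leaves its true place open.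

Compound 4 (`C#CCSc1nc(Sc2nc(C)cs2)c(C#N)c(-c2cc(OC)c(OC)c(OC)c2)n1`) changes one group (4-methyl-1,3-thiazol-2-yl in place of 1,3-benzothiazol-2-yl on a sulfur). Three measured swaps of this group bear on it: an at least 2.0-fold lower number from compound 1 to compound 2 (0.30 log units; that floor lies within the scatter), an at least 2.0-fold higher number from compound 2 to compound 3 (0.30 log units; that floor lies within the scatter) and a step that the two limits leave unreadable from compound 1 to compound 3. Compound 1, whose 4,5-dimethyl-1,3-thiazol-2-yl is the most similar group, gives a limit (> 20000 nM), so compound 4 is expected to stay near that limit, with no step beyond the scatter in this assay. The expected step is an at least 1.1-fold lower number from compound 3 to compound 4 (0.07 log units; that floor lies within the scatter) by this estimate. The estimate for compound 4 is 17000 nM (expected range 7000 nM to 40000 nM).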

Compound 4, half-maximal inhibitory concentration: > 20000 nM
Compound 4 was reported as a limit (the forecaster's own chance of this, stated with the estimate: 50%); at least 1.1-fold (0.07 log units) between middle value and limit.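

In this assay, compound 4 also gives only a limit, so a third thiazole-type group on this sulfur, 4-methyl-1,3-thiazol-2-yl, yields no readable number. The only readable comparison is an at least 2.0-fold higher number from compound 2 to compound 4 (0.30 log units; that floor lies within the scatter), so no step here is shown beyond the scatter. The steps from compound 1 and compound 3 to compound 4 cannot be read: the limit of > 20000 nM in this assay, at which 3 of the 4 values shown sit.

Still open, as far as these compounds go, is how far apart the compounds at the limit truly lie. Also open, from the compounds shown here alone, is whether a carboxylic acid or an amine on a short chain on this sulfur would give a number clearly below the limit.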